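Chlorophenyl swap on a compound at the assay limit

The compounds below may be only part of what the source reports. "The series", "measured", "known", "first", "only" and "open" are said of these compounds alone.

- Compound 1 `O=S(=O)(NCCNC(=S)Nc1cccc(Cl)c1)c1ccc(-c2ccccc2OCc2cccc(O)c2)s1` gives 17400 nM
- Compound 2 `COc1ccc(Oc2ccc(C(C)C)cc2-c2ccsc2S(=O)(=O)NCCNC(=S)Nc2ccc([N+](=O)[O-])cc2)cc1OC` gives 11400 nM
- Compound 3 `COc1ccc(NC(=O)NCCNS(=O)(=O)c2ccc(-c3ccccc3OCc3ccccc3)s2)cc1` gives > 50000 nM as a limit

All three values come from an ADME assay on HEK-293T cells (Homo sapiens) for cytotoxicity, read by CCK-8 assay, with a stated time of 48 h (a lower number here means a stronger inhibitor, a higher number a weaker inhibitor), and describe damage to cultured cells. Compound 3 stands at a limit and not at a number (the limit of > 50000 nM in this assay, at which 1 of the 3 values shown sits). Compound 1 and compound 2 lie within the usual scatter of each other.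

Compound 4 `O=S(=O)(NCCNC(=S)Nc1cccc(Cl)c1)c1ccc(-c2ccccc2OCc2ccccc2)s1` differs from compound 3 in one place, on an amine nitrogen whose other neighbour is a saturated chain carbon (a group of 10 heavy atoms (7 carbon, 1 nitrogen, 1 sulfur, 1 chlorine; one six-membered aromatic ring of carbon only) in place of a group of 11 heavy atoms (8 carbon, 1 nitrogen, 2 oxygen; one six-membered aromatic ring of carbon only), on an amine nitrogen). The (4-methoxyphenyl)carbamoyl group leaves, and a group holding sulfur and chlorine enters.

Compound 4 shares this entering group with compound 1 (17400 nM), so a value near that one seems likely. Among the compounds with values here, no pair of measured compounds shows this change directly. The expected change is a drop to a lower number, beyond the scatter (an at least 3.1-fold lower number from compound 3 to compound 4 (0.49 log units; beyond the scatter)). For compound 4 the estimated value is 16000 nM (expected range 7000 nM to 36000 nM).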

Compound 4, half-maximal inhibitory concentration: 10200 nM
For compound 4 the middle estimate is 1.6-fold (0.20 log units) above the measured one; the measured number falls inside the stated range.
By their numbers in this assay, from the lowest: compounds 4, 2 and 1 (each within the scatter of the next). At a limit, above all of these: compound 3.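

In this assay, within the data shown here, putting the group holding sulfur and chlorine in place of the (4-methoxyphenyl)carbamoyl group on the amine nitrogen gives an at least 4.9-fold lower number from compound 3 to compound 4 (0.69 log units; beyond the scatter) and so provides the first direct reading of this change. The value of compound 3 is a limit and not a number: the limit of > 50000 nM in this assay, at which 1 of the 4 values shown sits. Hydrogen in place of hydroxy on an aromatic carbon gives a 1.7-fold lower number from compound 1 to compound 4 (0.23 log units; within the scatter) and so shows no clear change in this number.

As far as these compounds go, it remains open which part of the entering group goes with the lower number, and whether a plain acetyl group or a longer chain on the amine nitrogen would behave like it or like the (4-methoxyphenyl)carbamoyl group. From the compounds shown here alone, it is also open whether an amine or a carboxylic acid on that aromatic carbon would leave the number as little changed as hydroxy does.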